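This account rests on a few compounds, and the source may have more. Where it says the series, first, only, none or still open, it means among the compounds named here.

Measured in an ADME assay on MT4 cells (Homo sapiens) for cytotoxicity (on this read-out lower numbers stand for higher toxicity in this test and higher numbers for lower toxicity in this test), both readings limits:
- Compound 1 `Cc1cc(C)cc(S(=O)(=O)n2c(SCC(=O)Nc3ccccc3Br)nc3ccccc32)c1`: >= 235000 nM
- Compound 2 `Cc1cc(C)cc(S(=O)(=O)n2c(SCC(=O)Nc3ccc(S(C)(=O)=O)cc3Cl)nc3ccccc32)c1`: > 221000 nM

Compound 2 has no numerical value on this read-out, only the limit > 221000 nM. Compound 3 `Cc1cc(C)cc(S(=O)(=O)n2c(SCC(=O)Nc3ccc(S(N)(=O)=O)cc3Cl)nc3ccccc32)c1` carries amino in place of methyl on a sulfonyl sulfur, so methylsulfonyl becomes sulfamoyl (amino in place of methyl on a sulfonyl sulfur). Going by the values given here, the only measured step is a step that the two limits leave unreadable from compound 1 to compound 2. It concerns the group on the amide-type nitrogen, the part of the structure that changes again here, but it offers no size to carry over. No step beyond the scatter is therefore expected in this assay, and the data suggest no direction. Another limit is the likeliest reading. The expected change is a number no higher from compound 2 to compound 3 (the limit leaves the size open). For compound 3 the estimated value is 220000 nM, with an expected range of 70000 nM to 260000 nM.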

Compound 3, half-maximal cytotoxic concentration: 25600 nM
Compound 3: the middle estimate sits 8.6-fold (0.93 log units) above what was measured; measured number outside the range, below it.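

In this assay, the sulfonyl sulfur proves to be a sensitive place, which the earlier limits could not show: amino in place of methyl gives an at least 8.6-fold lower number from compound 2 to compound 3 (0.93 log units; beyond the scatter), and higher toxicity in this test. Setting 2-chloro-4-sulfamoylphenyl against 2-bromophenyl on the amide-type nitrogen gives an at least 9.1-fold lower number from compound 1 to compound 3 (0.96 log units; beyond the scatter), while the step from compound 1 to compound 2 cannot be read, since both values are limits; the drop thus appears only with the sulfamoyl group, not with the methylsulfonyl group. Nothing measured here accounts for the drop.

From the compounds shown here alone, it remains open whether methylamino or dimethylamino on the sulfonyl sulfur would keep the lower number. A carboxylic acid in place of the sulfamoyl group is equally untested in the compounds shown.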